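This account rests on a few compounds, and the source may have more. Where it says the series, first, only, none or still open, it means among the compounds named here.

Compound 1 `Oc1ccc(-c2cc(-c3cccc(Cl)c3)nc(-c3ccccn3)c2)cc1`: 28200 nM
Compound 2 `Oc1cccc(-c2cc(-c3cccc(Cl)c3)nc(-c3ccccn3)c2)c1`: "not determined" (no result reported)
Compound 3 `Oc1cccc(-c2cc(-c3ccc(Cl)cc3)nc(-c3ccccn3)c2)c1`: 13500 nM

These three compounds share one core and differ only in where the hydroxy group sits on one phenyl ring and where the chlorine sits on another. In a functional assay on HCT-15 cells (Homo sapiens) for cytotoxicity, read by CCK-8 assay and cell counting, with a stated time of 2 days (a lower number here means a stronger inhibitor, a higher number a weaker inhibitor), compound 1 gives 28200 nM and compound 3 gives 13500 nM; both numbers are high, so neither compound is a strong inhibitor. In this assay compound 2 stands with "not determined" (no result reported), that is, without a number of its own, so its position can only be guessed from its close relatives, compound 1 and compound 3.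

Compound 4 `Oc1cccc(-c2cc(-c3ccsc3)nc(-c3cccc(Cl)c3)c2)c1` is made from compound 2 by one change: thiophen-3-yl in place of pyridin-2-yl on an aromatic carbon. For the measured compounds named here, because no pair of measured compounds shows what this exchange does in this assay, the direction is open; the expectation is a step of modest size, and quite possibly none beyond the usual scatter, around the weak level that compound 1 and compound 3 set. Compound 4 is therefore expected to give an estimated 18000 nM, within a range from 5000 nM to 60000 nM.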

Compound 4, half-maximal inhibitory concentration: 2510 nM
The estimate for compound 4 lay 7.2-fold (0.86 log units) above the measured number, outside the stated range (below it).
By their numbers in this assay, from the lowest: compound 4; then compound 3; then compound 1.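

No step can be read for compound 4: compound 2, its partner across one change, has no number of its own in this assay, and compound 1 and compound 3 differ from compound 4 in more than one place. On these data alone, what thiophen-3-yl in place of pyridin-2-yl does on its own stays open. Nothing shown explains the result of compound 4.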